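The source may report more compounds than this note shows. Statements on the series, on what has been measured and on what is new or still open speak of the compounds shown alone.

For the measured compounds named here, in an in vitro ADME assay on microsomes from liver (Homo sapiens) for pharmacokinetics (a lower number here means slower removal, a higher number faster removal of the compound), compound 1 `Cc1ccc(S(=O)(=O)N2C=CNC(=O)[C@H]2CC(=O)N[C@@H]2CCCc3ccccc32)cc1` gives 514 mL.min-1.g-1 and compound 2 `Cc1ccc(S(=O)(=O)N2C=CNC(=O)[C@H]2CC(=O)NC2CCCCC2C)cc1` gives 212 mL.min-1.g-1, which makes compound 2 the lower of the two numbers so far. Compound 3 `Cc1ccc(S(=O)(=O)N2C=CNC(=O)[C@H]2CC(=O)NC2CCOCC2(C)C)cc1` has not yet been measured. It differs from compound 2 on an amide-type nitrogen: a group of 8 heavy atoms (7 carbon, 1 oxygen; one six-membered non-aromatic ring with 1 hetero atom) in place of a group of 7 heavy atoms (7 carbon; one six-membered non-aromatic ring of carbon only), on an amide-type nitrogen. Going by the values given here, one measured step bears on this place, a 2.4-fold lower number from compound 1 to compound 2 (0.38 log units; beyond the scatter). That step is modest but beyond the scatter, and it involves a different pair of groups, so it offers a guide to size and no rule. A single step cannot fix the direction with confidence, but a further modest move towards a lower number is expected in this assay. The expected step is a 2.1-fold lower number from compound 2 to compound 3 (0.33 log units; beyond the scatter). For compound 3 the estimated value is 100 mL.min-1.g-1, with an expected range of 40 mL.min-1.g-1 to 230 mL.min-1.g-1.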

Compound 3, intrinsic clearance in microsomes: < 100 mL.min-1.g-1
Compound 3: a limit, no number; the forecaster's own chance of this, stated with the estimate: 5%; the middle value lies on the limit itself.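

In this assay compound 3 gives no number, only a limit: the limit of < 100 mL.min-1.g-1 in this assay, at which 1 of the 3 values shown sits.

For the compounds shown here, replacing 2-methylcyclohexyl with the six-membered ring holding a hetero atom, on the same amide-type nitrogen, gives an at least 2.1-fold lower number from compound 2 to compound 3 (0.32 log units; beyond the scatter), the first evidence at this position for a group that is not carbon only. Across the three groups shown the number falls in one direction, with no compound shown going against it, and the whole change amounts to an at least 5.1-fold lower number from compound 1 to compound 3 (0.71 log units; beyond the scatter).

The compounds shown leave open how much of the step belongs to the ring oxygen and how much to the rest of the change in the group, and how far the true value of compound 3 lies past its limit. Also open, as far as these compounds go, is how a ring amine such as piperidinyl, or an open alkyl chain, would read on this nitrogen.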